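1,3-Oxazol-2-yl in Place of 2,2,2-Trifluoroethyl

This account rests on a few compounds, and the source may have more. Where it says the series, first, only, none or still open, it means among the compounds named here.

In an ADME assay on LLC-PK1 cells (Sus scrofa) for permeability (on this read-out higher numbers stand for higher permeability and lower numbers for lower permeability), compound 1 (`C[C@]1(c2cc(NC(=O)c3ccc(Cl)cn3)cc(F)c2F)N=C(N)S[C@H]2C[C@H]21`) gives 13 10^-6 cm/s and compound 2 (`COC[C@]12C[C@H]1[C@@](C)(c1cc(NC(=O)c3cnc(OCCC(F)(F)F)cn3)cc(F)c1F)N=C(N)S2`) gives 23 10^-6 cm/s on the same read-out, so compound 2 stands within the scatter of compound 1. Compound 3 (`COC[C@]12C[C@H]1[C@@](C)(c1cc(NC(=O)c3cnc(OCc4ncco4)cn3)cc(F)c1F)N=C(N)S2`) carries 1,3-oxazol-2-yl in place of 2,2,2-trifluoroethyl on a saturated chain carbon bound to an oxygen on an aromatic ring. Going by the values given here, no measured pair shows this change, so only a slight downward move, not beyond the scatter, is expected in this assay here. The expected step, a 1.5-fold lower number from compound 2 to compound 3 (0.19 log units; within the scatter), is small. For compound 3 the estimate is 15 10^-6 cm/s (range 7 10^-6 cm/s to 30 10^-6 cm/s) on this read-out.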

Compound 3, apparent permeability: 48 10^-6 cm/s
Compound 3: the middle estimate sits 3.2-fold (0.51 log units) below what was measured, and the stated range ends below it.
By their numbers in this assay, from the lowest: compounds 1 and 2 (each within the scatter of the next); then compound 3.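

At the saturated chain carbon bound to an oxygen on an aromatic ring, this assay shows a 2.1-fold higher number from compound 2 to compound 3 (0.32 log units; beyond the scatter) on replacing 2,2,2-trifluoroethyl with 1,3-oxazol-2-yl, the only step shown here and one beyond the scatter. This position therefore accepts a five-membered aromatic ring with 2 hetero atoms and 2 hydrogen-bond acceptors without any loss on this read-out. No measurement given here accounts for the step.
As far as these compounds go, whether a phenyl ring, a 1,3-thiazol-2-yl ring or an amine at this carbon would match compound 3 remains open.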